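Same atoms, joined differently: compound 2 to compound 3

This account rests on a few compounds, and the source may have more. Where it says the series, first, only, none or still open, it means among the compounds named here.

Compound 2 `C1=C(CCN2CCN(c3cccc4c3OCCO4)CC2)c2ccccc2C1` gives 251 nM in an assay on isolated protein for binding affinity to 5-hydroxytryptamine receptor 1B (Rattus norvegicus) (on this read-out higher numbers stand for weaker inhibition and lower numbers for stronger inhibition), the smaller of the two numbers recorded, although compound 1 `c1ccc2c(c1)CCC2CCN1CCN(c2cccc3c2OCCO3)CC1`, with 417 nM, lies within the scatter of it, as the step of a 1.7-fold lower number from compound 1 to compound 2 (0.22 log units; within the scatter) shows. Compound 3 `C1=C(CCN2CCN(c3cccc4c3OCCO4)CC2)Cc2ccccc21` contains the same atoms as compound 2, joined differently: a group of 9 heavy atoms (9 carbon; one five-membered non-aromatic ring of carbon only, one six-membered aromatic ring of carbon only) in place of a group of 9 heavy atoms (9 carbon; one five-membered non-aromatic ring of carbon only, one six-membered aromatic ring of carbon only), on a saturated chain carbon, two bonds along the chain from an amine nitrogen in a ring. Within the data shown here, the only measured step, from compound 1 to compound 2, also swapped one such group for another and stayed within the scatter, so in this assay no step beyond the scatter is expected, a 1.1-fold higher number from compound 2 to compound 3 (0.05 log units; within the scatter). Compound 3 is therefore estimated at 280 nM, with a range from 100 nM to 800 nM.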

Compound 3, inhibition constant: 933 nM
The estimate for compound 3 lay 3.3-fold (0.52 log units) below the measured number; measured number above the stated range.
By their numbers in this assay, from the lowest: compounds 2 and 1 (each within the scatter of the next); then compound 3.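

At this place, on a saturated chain carbon, two bonds along the chain from an amine nitrogen in a ring, rejoining the same atoms can change the number in this assay: the change gives a 3.7-fold higher number from compound 2 to compound 3 (0.57 log units; beyond the scatter) and, against the saturated group, a 2.2-fold higher number from compound 1 to compound 3 (0.35 log units; beyond the scatter). Both steps are modest, but the earlier swap of one such group for another stayed within the scatter. Nothing shown explains this difference. Going by these compounds, whether a hydroxyl on the five-membered ring or a longer chain would lower or raise the number remains open.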